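This account rests on a few compounds, and the source may have more. Where it says the series, first, only, none or still open, it means among the compounds named here.

Compound 1, `COc1ncnc2c1c(I)cn2[C@@H]1O[C@H](CO)[C@@H](O)[C@H]1O`. In a functional assay on CEM-DNR-bulk cells (Homo sapiens), read by MTT assay, with a stated time of 72 h (a lower number here means a stronger inhibitor, a higher number a weaker inhibitor), compound 1 gives > 20000 nM, which is a limit of the assay and not a number.
Compound 2, `CNc1ncnc2c1c(-c1cccs1)cn2[C@@H]1O[C@H](CO)[C@@H](O)[C@H]1O`. In this assay compound 2 gives > 20000 nM, again a limit of the assay and not a number.

Compound 1 therefore stands nowhere definite on the numbers shown: its own value is only a limit, the one other value shown is a limit too, and the limit of > 20000 nM in this assay, at which 2 of the 2 values shown sit, is all the data offer. Compound 3, `COc1ncnc2c1c(-c1ccoc1)cn2[C@@H]1O[C@H](CO)[C@@H](O)[C@H]1O`, has not yet been measured in this assay. It differs from compound 1 in one place: furan-3-yl in place of iodo on an aromatic carbon. Within the data shown here, no step between measured compounds exists to guide an expectation, and compound 2, which also carries a five-membered aromatic ring in place of iodo, sits at the limit. The step of a number no higher from compound 1 to compound 3 (the limit leaves the size open) is therefore expected to be none beyond the scatter, most likely ending at another limit. Compound 3 is estimated at 20000 nM, with a range from 5000 nM to 80000 nM.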

Compound 3, half-maximal inhibitory concentration: > 20000 nM
Compound 3 gave a limit, no number (the forecaster's own chance of this, stated with the estimate: 75%); the middle value sits exactly at the limit.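

Among these compounds, compound 1 and compound 3 each give a limit of the assay and not a number, so no step between them can be read. Whether any group on the shared core would give a measurable value in this assay stays open, as all the data show is a single ceiling: the limit of > 20000 nM in this assay, at which 3 of the 3 values shown sit.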